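The source may hold more compounds than are shown below. What is called first, only, known or untested is meant among the compounds shown, and "the series" means these compounds.

Among the compounds with values here, compound 1 `CC(C)OC(=O)N1CCC(Oc2ncnc3c2CCN3c2ccc(S(C)(=O)=O)cc2F)CC1` is one of two compounds measured in a functional assay on CHO-K1 cells for agonist activity at Glucose-dependent insulinotropic receptor (Homo sapiens), read by a luciferase reporter, with a stated time of 5 h (a lower number here means that less compound is needed, a higher number that more compound is needed for the effect), and in that assay compound 1 gives 50.1 nM, the lowest of the two numbers. The other measured compound is compound 2 `CC(C)OC(=O)N1CCC(Oc2ncnc3c2CCN3c2ccc(S(C)(=O)=O)cc2)CC1`, which in this assay gives 126 nM; the step from compound 1 to compound 2 is a 2.5-fold higher number from compound 1 to compound 2 (0.40 log units; beyond the scatter), a modest change that concerns the fluoro on an aromatic carbon and nothing else.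

Compound 3 `CS(=O)(=O)c1ccc(N2CCc3c(OC4CCN(C(=O)OCCF)CC4)ncnc32)c(F)c1` differs from compound 1 at a different place: 2-fluoroethyl in place of isopropyl on an oxygen next to a carbonyl group. The carbamate oxygen carries a chain of the same length as before, with a fluorine in place of one carbon, and the rest of the shared core is unchanged. Within the data shown here, no measured step bears on a change at this oxygen; the single known step sits on the aromatic ring and says nothing about the carbamate. In this assay compound 3 is therefore expected to show a step of about a 1.4-fold higher number from compound 1 to compound 3 (0.15 log units; within the scatter), which stays within the scatter, so the estimate for compound 3 is 70 nM, in a range from 25 nM to 200 nM.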

Compound 3, half-maximal effective concentration: 501 nM
Beside the measured number, compound 3's estimate is 7.2-fold (0.85 log units) below it; the measured number lies above the stated range.
By their numbers in this assay, from the lowest: compound 1; then compound 2; then compound 3.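

At this oxygen next to a carbonyl group, the choice of group proves to matter: 2-fluoroethyl in place of isopropyl gives a 10-fold higher number from compound 1 to compound 3 (1.00 log units; beyond the scatter) in this assay even though both groups have 3 heavy atoms and no ring. Within the data shown here, this is a larger step than a 2.5-fold higher number from compound 1 to compound 2 (0.40 log units; beyond the scatter) and shows that the end of compound 1 carrying the isopropyl group also responds to change, which the single earlier step on the aromatic carbon could not show. No independent measurement accounts for the size of the step from isopropyl to 2-fluoroethyl.

The compounds shown do not separate the contribution of the fluorine from that of the change from a branched group to a straight chain, as neither an ethyl nor a propyl group on this oxygen stands among them. They also leave open how a longer chain or a cyclopropyl group would behave here, and whether hydrogen in place of fluoro on the aromatic carbon would give a similar step in a compound that carries 2-fluoroethyl.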